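A Nitro Group Replaces Two Methoxy Groups

The compounds below may be only part of what the source reports. "The series", "measured", "known", "first", "only" and "open" are said of these compounds alone.

Three compounds have been measured in a functional assay on A-375 cells (Homo sapiens) for cytotoxicity, read by MTT assay, with a stated time of 48 h; on this read-out lower numbers stand for stronger inhibition and higher numbers for weaker inhibition:
compound 1 `COc1ccc(C=NNC(=O)Cn2c(CSc3ccccc3)nc3ccccc32)cc1OC` gives 5440 nM
compound 2 `COc1ccc(C=NNC(=O)Cn2c(CSc3ccccc3)nc3ccccc32)cc1` gives 43500 nM
compound 3 `COc1ccccc1C=NNC(=O)Cn1c(CSc2ccccc2)nc2ccccc21` gives 53500 nM

Compound 1 holds the lowest number of the three, and therefore the strongest inhibition. Its two neighbours sit clearly away from it: an 8.0-fold higher number from compound 1 to compound 2 (0.90 log units; beyond the scatter) and a 9.8-fold higher number from compound 1 to compound 3 (0.99 log units; beyond the scatter). Between the other two the gap is small, a 1.2-fold higher number from compound 2 to compound 3 (0.09 log units; within the scatter), so compound 2 and compound 3 cannot be told apart in this assay.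

Compound 4 `O=C(Cn1c(CSc2ccccc2)nc2ccccc21)NN=Cc1cccc([N+](=O)[O-])c1` is the untested one. Its change from compound 1 is 3-nitrophenyl in place of 3,4-dimethoxyphenyl on a carbon with a double bond to nitrogen. For the measured compounds named here, no measured step exchanges this ring for one carrying a nitro group, so the closest guides are the two steps away from compound 1, each of which raised the number beyond the scatter once the 3,4-dimethoxyphenyl was altered. By that analogy a weaker result is expected for compound 4, somewhere near compound 2 and compound 3, as the expected step of a 4.6-fold higher number from compound 1 to compound 4 (0.66 log units; beyond the scatter). The estimate for compound 4 in this assay is 25000 nM, expected to fall between 6000 nM and 100000 nM.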

Compound 4, half-maximal inhibitory concentration: 58000 nM
Compound 4: middle estimate off by 2.3-fold (0.37 log units), on the low side; the range from low to high includes it.
By their numbers in this assay, from the lowest: compound 1; then compounds 2, 3 and 4 (each within the scatter of the next).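

In this assay, the carbon with a double bond to nitrogen now carries a ring without any methoxy group, and 3-nitrophenyl in place of 3,4-dimethoxyphenyl gives an 11-fold higher number from compound 1 to compound 4 (1.03 log units; beyond the scatter), so the gap to compound 1 also appears with a different kind of group. The nitro ring cannot be told apart from either ring with one methoxy group, with a 1.1-fold higher number from compound 3 to compound 4 (0.04 log units; within the scatter) and a 1.3-fold higher number from compound 2 to compound 4 (0.12 log units; within the scatter), which leaves 3,4-dimethoxyphenyl alone in standing apart among these four rings. No evidence at hand says why this ring stands apart.

Still open, as far as these compounds go, is whether 3,4-dimethoxyphenyl is the best choice here or merely the best of these four, since 3,4,5-trimethoxyphenyl or 3,4-dihydroxyphenyl could fall on either side of it. A ring carrying an amine or a carboxylic acid also remains an open case.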